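The source may report more compounds than this note shows. Statements on the series, on what has been measured and on what is new or still open speak of the compounds shown alone.

Measured so far:
Compound 1 `O=C1NC(=O)C(c2ccccc2)CC1c1ccccc1`, in a functional assay on the whole organism (strain Swiss albino) for inhibition, with Mus musculus as the target, in the maximal electroshock model, with a stated time of 2 h, at a dose of 25 mg/kg by the intraperitoneal route (a higher number here means more inhibition at the dose given (going by the name of the read-out), a lower number less inhibition), compound 1 gives 70.2%.
Compound 2 `O=C1C(c2ccccc2)CC(c2ccccc2)C(=O)N1c1ccccc1`, compound 2 gives 38.3%.
Compound 3 `O=C1C(c2ccccc2)CC(c2ccccc2)C(=O)N1Cc1ccccc1`, compound 3 gives 64.5%.

Compound 3 stands second highest of the three; its nearest neighbour is compound 1, and the two lie within the scatter of each other, as a number 5.7 percentage points lower from compound 1 to compound 3 (within the scatter) shows, while compound 2 is the furthest away and beyond the scatter. The unmeasured compound 4 `O=C1C(c2ccccc2)CC(c2ccccc2)C(=O)N1c1cccc(Cl)c1` differs from compound 3 in one place: 3-chlorophenyl in place of benzyl on an amide-type nitrogen in a ring. Among the compounds with values here, two measured steps bear on this. The benzyl group on the ring nitrogen gave a number 26.2 percentage points higher from compound 2 to compound 3 (beyond the scatter), and the phenyl on that nitrogen gave a number 31.9 percentage points lower from compound 1 to compound 2 (beyond the scatter). Within the data shown here, compound 4 carries a 3-chlorophenyl rather than a benzyl on that nitrogen, so the step it most resembles is the reverse of the one from compound 2 to compound 3; the chlorine has no counterpart among the measured compounds. The expected step is therefore a modest drop, a number 20.5 percentage points lower from compound 3 to compound 4 (beyond the scatter), beyond the scatter. Compound 4 is estimated at 44%, with a range from 30% to 62%.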

Compound 4, a percentage reported as inhibition, in the whole organism at one dose (the size of the read-out at that dose, not a potency): 32.2%
Compound 4: the middle estimate sits 11.8 percentage points above what was measured, and the stated range covers the measured number.
By their numbers in this assay, from the lowest: compounds 4 and 2 (each within the scatter of the next); then compounds 3 and 1 (each within the scatter of the next).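

In this assay, the chloro on the aromatic ring gives a step that stays within the scatter, a number 6.1 percentage points lower from compound 2 to compound 4 (within the scatter), so at this position the 3-chlorophenyl group reads the same as the plain phenyl. Both large steps, a number 32.3 percentage points lower from compound 3 to compound 4 (beyond the scatter) and a number 38 percentage points lower from compound 1 to compound 4 (beyond the scatter), now show that among these four compounds, the two with an aromatic ring bonded directly to the amide-type nitrogen sit low, while the benzyl and the amide hydrogen sit high. Nothing available explains why these groups differ at this nitrogen.

Still open, going by these compounds, is whether this holds for other substituents on that aromatic ring, such as methoxy or nitro, or for a chloro on the benzyl group. On these data alone, a longer chain such as phenethyl, or one ending in an amine, also remains unexplored at this nitrogen.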